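The compounds below may be only part of what the source reports. "The series", "measured", "known", "first", "only" and "open" are said of these compounds alone.

Values in a functional assay on SR cells (Homo sapiens) for inhibition; a lower number here means a stronger inhibitor of growth, a higher number a weaker inhibitor of growth:
- compound 1 `COc1cc(/C=C/c2ccc(S(N)(=O)=O)cc2)cc(OC)c1`: 19700 nM
- compound 2 `NS(=O)(=O)c1ccc(/C=C/c2ccc(F)cc2)cc1`: 10500 nM

Compound 2 gives 10500 nM and compound 1 gives 19700 nM. Among the compounds with values here, these two values lie within the scatter of each other, so compound 2 stands level with the only other measured compound.

The next compound is compound 3 `CN(C)c1ccc(/C=C/c2ccc(S(N)(=O)=O)cc2)cc1`, with dimethylamino in place of fluoro on an aromatic carbon, para to a large group: dimethylamino in place of fluoro on an aromatic carbon.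

Within the data shown here, no measured pair differs in one place only, so the data give no direct guide to the size of this change in this assay. Compound 2 at 10500 nM and compound 1 at 19700 nM carry different groups and still show no separation, which gives no reason to expect a large step. A moderate move to a lower number is expected, though a result within the scatter of compound 2 would not be surprising.

The expected change is a 2.1-fold lower number from compound 2 to compound 3 (0.32 log units; beyond the scatter).

For compound 3 the estimated value is 5000 nM, with an expected range of 1200 nM to 20000 nM.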

Compound 3, concentration for 50% growth inhibition: 8580 nM
Beside the measured number, compound 3's estimate is 1.7-fold (0.23 log units) below it; the measured number falls inside the stated range.
By their numbers in this assay, from the lowest: compounds 3, 2 and 1 (each within the scatter of the next, the first and the last beyond it).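

In this assay, within the data shown here, this is the first pair that differs in one place only, and dimethylamino in place of fluoro on an aromatic carbon, para to a large group, gives a 1.2-fold lower number from compound 2 to compound 3 (0.09 log units; within the scatter). Among these compounds, this is the first direct reading at this position: exchanging a single fluorine for a group of three heavy atoms that adds one hydrogen-bond acceptor leaves the two compounds without separation, so this one change does not distinguish the two groups in this read-out. No measured evidence accompanies this result to account for the two groups reading alike.

As far as these compounds go, it remains open whether any group at this position can move the number beyond the scatter, since a single pair samples only these two substituents, and a carboxylic acid, a primary amine or a longer alkoxy chain in the same place would test that more widely. Also open is how much the sulfonamide contributes to growth inhibition, as it is common to all the compounds shown and a carboxylic acid in its place would give a first reading.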